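This account rests on a few compounds, and the source may have more. Where it says the series, first, only, none or still open, it means among the compounds named here.

Measured to date in an assay for inhibition of beta-glucuronidase (Bos taurus), read by spectrophotometry, with a stated time of 30 min; on this read-out higher numbers stand for weaker inhibition and lower numbers for stronger inhibition:
compound 1 `O=[N+]([O-])c1ccc(S(=O)(=O)Nc2cnc3ccccc3c2)cc1` gives 31600 nM;
compound 2 `CCCc1ccc(S(=O)(=O)Nc2cnc3ccccc3c2)cc1` gives 27200 nM;
compound 3 `O=[N+]([O-])c1ccc(S(=O)(=O)Oc2cccc3cccnc23)cc1` gives 15400 nM.

Between compound 1 and compound 2 the one structural change is propyl in place of nitro on an aromatic carbon, and it produced a 1.2-fold lower number from compound 1 to compound 2 (0.07 log units; within the scatter). Compound 3 carries a different core; the difference between the two cores is not broken down here. Compound 4 `CCCc1ccc(S(=O)(=O)Oc2cccc3cccnc23)cc1`, not yet measured, differs from compound 3 by propyl in place of nitro on an aromatic carbon, with the place described in the same words as for the earlier pair, so it is the same change on the second core. On that basis the step is expected to be small: a 1.2-fold lower number from compound 3 to compound 4 (0.07 log units; within the scatter), set beside the measured 1.2-fold lower number from compound 1 to compound 2 (0.07 log units; within the scatter). The estimated value for compound 4 in this assay is 13000 nM, with an expected range from 5000 nM to 35000 nM.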

Compound 4, half-maximal inhibitory concentration: 84400 nM
Compound 4: the middle estimate sits 6.5-fold (0.81 log units) below what was measured, and the stated range ends below it.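

On the core of compound 3, propyl in place of nitro on an aromatic carbon gives a 5.5-fold higher number from compound 3 to compound 4 (0.74 log units; beyond the scatter) in this assay. The change therefore does not carry over unchanged between these cores, and a step read on one core is a poor guide to the other: the same change on two cores in this assay, a 1.2-fold lower number (0.07 log units; within the scatter) from compound 1 to compound 2 and a 5.5-fold higher number (0.74 log units; beyond the scatter) from compound 3 to compound 4, 6.4-fold (0.80 log units) apart, beyond the scatter of two such steps. This rests on a single pair of steps: it shows that the size of the step depends on the core here, but not which part of the core difference is responsible, nor whether the same holds for other groups.

Open, from the compounds shown here alone, is how an amine or a carboxylic acid at the same place would behave on each core. Also open, going by these compounds, is which part of the difference between the cores goes with the difference in the steps.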